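The source may report more compounds than this note shows. Statements on the series, on what has been measured and on what is new or still open speak of the compounds shown alone.

Measured compounds:

compound 1, `CCCC(=O)C1=C(C)NC(=O)NC1c1ccco1`, 1%
compound 2, `CC1=C(C(=O)CC(C)C)C(c2ccco2)NC(=O)N1`, 31%
compound 3, `CCC(CC)OC(=O)C1=C(C)NC(=O)NC1c1ccsc1`, 6%

The read-out throughout is an assay on membranes from HeLa cells for displacement of a labelled ligand from adenosine receptor A3 (Homo sapiens), read by scintillation counting, with a stated time of 180 min, tested at 1 uM; on this read-out lower numbers stand for less inhibition and higher numbers for more inhibition at the one concentration tested (going by the name of the read-out). Compound 2 gives 31%. Compound 1 carries hydrogen in place of methyl on a saturated chain carbon bound to two saturated chain carbons, and the step of a number 30 percentage points lower from compound 2 to compound 1 (beyond the scatter). Compound 3 shares a change of the same kind only in part: it carries a different ketone-side group and a different ring, and the difference between the core of compound 2 and the core of compound 3 is not broken down here. Compound 3 gives 6%, close to the value of compound 1 and well apart from compound 2.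

Compound 4, `CCC(C)OC(=O)C1=C(C)NC(=O)NC1c1ccsc1`, is not yet measured. It differs from compound 3 by hydrogen in place of methyl on a saturated chain carbon, two bonds along the chain from an oxygen next to a carbonyl group. This is the same kind of change as that from compound 2 to compound 1, but not the same: there the place was a saturated chain carbon bound to two saturated chain carbons, here it is a saturated chain carbon two bonds along the chain from an oxygen next to a carbonyl group. The earlier step went downward by a modest amount, but compound 3 already sits at a low reading, so the room for a further fall is small. Compound 4 is therefore expected to show roughly a number 2 percentage points lower from compound 3 to compound 4 (within the scatter). The estimate for compound 4 is 4%, expected to lie between 0% and 15%, resting on the value of compound 3 of 6%.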

Compound 4, a percentage reported as inhibition, at one concentration (the size of the read-out at that concentration, not a potency): 7%
For compound 4 the middle estimate is 3 percentage points below the measured one, within the range that was stated.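

In this assay, putting hydrogen in place of methyl on the chain of the ester side leaves the reading essentially where it was, a number 1 percentage points higher from compound 3 to compound 4 (within the scatter), whereas the same kind of change on the chain of the ketone side of the other pair gave a number 30 percentage points lower from compound 2 to compound 1 (beyond the scatter). The two outcomes do not agree: the same change on two cores in this assay, a number 30 percentage points lower (beyond the scatter) from compound 2 to compound 1 and a number 1 percentage points higher (within the scatter) from compound 3 to compound 4, 31 percentage points apart, beyond the scatter of two such steps This shows that, in this series, the result of removing this methyl on one core cannot be carried over to another, although it does not show what sets the two results apart, since the two pairs differ both in their cores and in the place of the change, and each outcome rests on a single pair of compounds.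

The compounds shown leave open whether the ester side of the core of compound 4 responds to any change at all, for instance a longer chain, a cyclohexyl group or an amine in place of sec-butyl. They also leave open whether the methyl removal would give a step beyond the scatter on the ester side of a core that reads higher in this assay, or whether the larger step stays confined to the ketone side.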